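Amide variation on a shared aminothiophene core

The compounds below may be only part of what the source reports. "The series", "measured", "known", "first", "only" and "open" are said of these compounds alone.

The series shares one core, shown in compound 1 `Nc1sc(-c2ccc(Cl)cc2)c(-c2ccc(Cl)cc2)c1C(=O)N1CCCCC1=O`, compound 2 `Nc1sc(-c2ccc(Cl)cc2)c(-c2ccc(Cl)cc2)c1C(=O)NC1CCC1` and compound 3 `Nc1sc(-c2ccc(Cl)cc2)c(-c2ccc(Cl)cc2)c1C(=O)N1CCC(=O)CC1=O`; compound 4 `Nc1sc(-c2ccc(Cl)cc2)c(-c2ccc(Cl)cc2)c1C(=O)N1CCCC1` is unmeasured. In a functional assay on PC-3 cells (Homo sapiens) for inhibition, read by sulforhodamine B assay, with a stated time of 72 h (a lower number here means a stronger inhibitor, a higher number a weaker inhibitor), compound 1 gives 4940 nM, compound 2 gives 24800 nM and compound 3 gives 9230 nM. Compound 2 stands weakest, with a 5.0-fold higher number from compound 1 to compound 2 (0.70 log units; beyond the scatter) and, in the other direction, a 2.7-fold lower number from compound 2 to compound 3 (0.43 log units; beyond the scatter); the step of a 1.9-fold higher number from compound 1 to compound 3 (0.27 log units; within the scatter) between the two cyclic amides stays small. Compound 4 differs from compound 2 by pyrrolidin-1-yl in place of cyclobutylamino on a carbonyl carbon. Both measured cyclic tertiary amides gave lower numbers than compound 2, so in this assay a modest lowering is expected for compound 4, roughly a 2.9-fold lower number from compound 2 to compound 4 (0.47 log units; beyond the scatter). The estimate for compound 4 is 8500 nM, expected between 3000 nM and 25000 nM.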

Compound 4, half-maximal inhibitory concentration: 6220 nM
For compound 4 the middle estimate is 1.4-fold (0.14 log units) above the measured one, and the stated range covers the measured number.
By their numbers in this assay, from the lowest: compounds 1, 4 and 3 (each within the scatter of the next); then compound 2.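

In this assay, the pyrrolidin-1-yl amide shows that a cyclic amide with no ring carbonyl still lowers the number, with a 4.0-fold lower number from compound 2 to compound 4 (0.60 log units; beyond the scatter). The ring carbonyls of compound 1 and compound 3 give no readable gain over this plain ring, with a 1.3-fold higher number from compound 1 to compound 4 (0.10 log units; within the scatter) and a 1.5-fold lower number from compound 3 to compound 4 (0.17 log units; within the scatter). No supporting measurement explains these steps.

The change from cyclobutylamino to pyrrolidin-1-yl removes the amide hydrogen and alters the ring together, and these compounds do not separate the two. An open-chain dimethylamino amide or an N-methylcyclobutylamino amide would bear on that question.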